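This account rests on a few compounds, and the source may have more. Where it says the series, first, only, none or still open, it means among the compounds named here.

In a functional assay on Jurkat cells for inhibition of nuclear factor NF-kappa-B complex (Homo sapiens) (a higher number here means a weaker inhibitor, a lower number a stronger inhibitor), compound 1 `CCOC(=O)c1cnc(-c2ccccc2)nc1N(C)N1C(=O)C=C(C)C1=O` gives 2000 nM.
In this assay compound 2 `CCOC(=O)c1cnc(-c2cccs2)nc1N(C)N1C(=O)C=C(C)C1=O` gives 1000 nM.
In this assay compound 3 `CCOC(=O)c1cnc(-c2ccc(F)cc2)nc1N(C)N1C(=O)C=C(C)C1=O` gives 3000 nM.

Compound 3 has the highest of the three numbers. Its nearest neighbour is compound 1, with a step that stays within the scatter, a 1.5-fold higher number from compound 1 to compound 3 (0.18 log units; within the scatter); its furthest is compound 2, with a modest step beyond the scatter, a 3.0-fold higher number from compound 2 to compound 3 (0.48 log units; beyond the scatter). The remaining step, a 2.0-fold lower number from compound 1 to compound 2 (0.30 log units; within the scatter), is also within the scatter. Every measured change so far either swaps one aromatic group for another or adds a fluoro to one.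

Compound 4 `CCOC(=O)c1cnc(CC)nc1N(C)N1C(=O)C=C(C)C1=O` differs from compound 3 by ethyl in place of 4-fluorophenyl on an aromatic carbon. Within the data shown here, none of the measured steps bears directly on this change: each measured compound keeps an aromatic ring between the two ring nitrogen atoms, and none replaces it with a chain. The small differences among those aromatic groups therefore give no guide to what removing the ring does. With this gap in the data, compound 4 is expected to give a higher number than compound 3, with wide uncertainty, the estimated step being a 2.0-fold higher number from compound 3 to compound 4 (0.30 log units; within the scatter). Compound 4 is accordingly estimated at 6000 nM in this assay, with a range from 1500 nM to 25000 nM.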

Compound 4, half-maximal inhibitory concentration: 10000 nM
Beside the measured number, compound 4's estimate is 1.7-fold (0.22 log units) below it; the range from low to high includes it.
By their numbers in this assay, from the lowest: compounds 2, 1 and 3 (each within the scatter of the next, the first and the last beyond it); then compound 4.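

Among these compounds, at the position between two ring nitrogen atoms, para to an ethoxycarbonyl group, the earlier compounds showed only exchanges of one aromatic group for another, whereas ethyl gives a higher number in this assay than each of the three aromatic groups: against 4-fluorophenyl (a 3.3-fold higher number from compound 3 to compound 4 (0.52 log units; beyond the scatter)), against phenyl (a 5.0-fold higher number from compound 1 to compound 4 (0.70 log units; beyond the scatter)) and against thiophen-2-yl (a 10-fold higher number from compound 2 to compound 4 (1.00 log units; beyond the scatter)). All three steps lie beyond the scatter, making compound 4 the weakest of the four inhibitors and showing that, in this series, this chain does not stand in for any of the three aromatic groups. Nothing measured here explains the loss.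

The change removes an aromatic ring and also shortens the substituent from 7 heavy atoms to 2, so these compounds cannot separate the two, and a saturated ring such as cyclohexyl or a longer chain such as butyl would be needed to tell them apart. They also leave open how an amine or a carboxylic acid at this position would compare, and whether any aromatic group here would go further than thiophen-2-yl.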